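The compounds below may be only part of what the source reports. "The series", "measured", "known", "first", "only" and "open" are said of these compounds alone.

Measured so far:
compound 1 `C=CCO/N=C/c1c(N)ncnc1Oc1ccc(NC(=O)C2(C(=O)Nc3ccc(F)cc3)CC2)cc1F` — 3.65
compound 2 `CC(O)CO/N=C/c1c(N)ncnc1Oc1ccc(NC(=O)C2(C(=O)Nc3ccc(F)cc3)CC2)cc1F` — 2.75

Compound 2 stands lowest of the two numbers in a physicochemical assay for lipophilicity, using the shake flask method; on this read-out lower numbers stand for lower lipophilicity and higher numbers for higher lipophilicity; its nearest neighbour is compound 1, and the step of a number 0.90 log units lower from compound 1 to compound 2 (beyond the scatter) is the only measured one at this position. Compound 3 `CCOC(=O)CO/N=C/c1c(N)ncnc1Oc1ccc(NC(=O)C2(C(=O)Nc3ccc(F)cc3)CC2)cc1F` is the next member, unmeasured in this assay. The change from compound 2 is ethoxycarbonyl in place of 1-hydroxyethyl on a saturated chain carbon bound to an oxygen on an unsaturated carbon. Among the measured compounds shown here, the one step that bears on it is a number 0.90 log units lower from compound 1 to compound 2 (beyond the scatter), where a hydroxyl-bearing group entered at the same place and the number fell by a modest amount beyond the scatter. Compound 3 removes that hydroxyl group again but brings in an ester with two acceptors and no donor, so a step back upward is expected, probably smaller than a full reversal. Compound 3 is estimated at 3.35, in the range 2.95 to 3.75, an expected step of a number 0.60 log units higher from compound 2 to compound 3 (beyond the scatter).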

Compound 3, partition coefficient: 3.15
For compound 3 the middle estimate is 0.20 log units above the measured one, and the stated range covers the measured number.
By their numbers in this assay, from the lowest: compound 2; then compound 3; then compound 1.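

Working notes on the side chain: in this assay, ethoxycarbonyl on the saturated chain carbon bound to an oxygen on an unsaturated carbon gives a number 0.40 log units higher from compound 2 to compound 3 (beyond the scatter), so exchanging 1-hydroxyethyl at this place moves the number upward. With vinyl as the reference, the same group gives a number 0.50 log units lower from compound 1 to compound 3 (beyond the scatter), which places compound 3 between compound 2 and compound 1; a group with 0 hydrogen-bond donors therefore does not return the number to the level of compound 1. No measured information accounts for this order.

Still open, as far as these compounds go, is where a carboxylic acid or an amine at this place would fall in this assay. From the compounds shown here alone, a longer chain in the ester is also open, as is whether the order of these three groups would hold on another core.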